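Ethyl in place of methyl on the aryl substituent

A few compounds are considered here, and "the series" means these few. Any claim that something is new, unique, unknown or untested is made for them only; others in the source may bear on it.

Measured compounds:
compound 1 `O=C1C=CC(OCC(F)(F)F)N1c1ccc(C(F)(F)F)cc1` — 8390 nM
compound 2 `CC(C)c1ccc(N2C(=O)C=CC2OCC(F)(F)F)cc1` — 9570 nM
compound 3 `Cc1ccc(N2C(=O)C=CC2OCC(F)(F)F)cc1` — 13700 nM

In a functional assay on A549 cells (Homo sapiens) for inhibition (a lower number here means a stronger inhibitor, a higher number a weaker inhibitor), compound 3 gives the highest of the three numbers, but its steps to the others are small: a 1.4-fold higher number from compound 2 to compound 3 (0.16 log units; within the scatter) and a 1.6-fold higher number from compound 1 to compound 3 (0.21 log units; within the scatter). All three compounds therefore sit in the same band, and none can be called weaker or stronger than another.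

Compound 4 `CCc1ccc(N2C(=O)C=CC2OCC(F)(F)F)cc1` is not yet measured. It differs from compound 3 by methyl in place of hydrogen on a saturated chain carbon bound to an aromatic carbon. The measured steps that bear on this change are the ones along the same chain of substituents on the aromatic carbon: a 1.4-fold higher number from compound 2 to compound 3 (0.16 log units; within the scatter) and a 1.1-fold higher number from compound 1 to compound 2 (0.06 log units; within the scatter). Both are within the usual scatter, so growing the group from methyl to ethyl, which lies between methyl and isopropyl in size, is expected to move this assay by no more than the scatter, if at all, and in no firm direction.

The estimate for compound 4 is therefore 11500 nM, with a range from 5000 nM to 26000 nM, an expected step of a 1.2-fold lower number from compound 3 to compound 4 (0.08 log units; within the scatter).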

Compound 4, half-maximal inhibitory concentration: 8090 nM
The estimate for compound 4 lay 1.4-fold (0.15 log units) above the measured number; low and high end bracket the measured number.
By their numbers in this assay, from the lowest: compounds 4, 1, 2 and 3 (each within the scatter of the next).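

Ethyl adds a further group at this aromatic carbon, and in this assay the methyl to ethyl change gives a 1.7-fold lower number from compound 3 to compound 4 (0.23 log units; within the scatter), so one more carbon on the saturated chain does not separate the two compounds. The comparisons with the other groups tell the same story: isopropyl to ethyl gives a 1.2-fold lower number from compound 2 to compound 4 (0.07 log units; within the scatter) and trifluoromethyl to ethyl gives a 1.0-fold lower number from compound 1 to compound 4 (0.02 log units; within the scatter), which means that methyl, ethyl, isopropyl and trifluoromethyl cannot be told apart here. Nothing available explains why these groups give such similar numbers.

Still open, as far as these compounds go, is whether a different kind of group at this aromatic carbon, such as an amine, a carboxylic acid or a longer chain, would move the number beyond the scatter. The compounds shown also say nothing about changes elsewhere on the shared core, which stays the same throughout.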